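Series notes: return from a benzyl to a directly bound aryl

The compounds below may be only part of what the source reports. "The series", "measured", "known", "first", "only" and "open" are said of these compounds alone.

Going by the values given here, compound 2 `C=C(Br)C(=O)Nc1cccc(-c2cn3nc(Cc4ccc(OC)cc4)sc3n2)c1` gives 1400 nM in a functional assay on L1210 cells (Mus musculus) for inhibition, read by cell counting, with a stated time of 2 days (a higher number here means a weaker inhibitor, a lower number a stronger inhibitor), the highest of the two numbers so far in this assay. Its nearest neighbour is compound 1 `C=C(Br)C(=O)Nc1cccc(-c2cn3nc(-c4ccc(OC)c(OC)c4)sc3n2)c1`, which in this assay gives 42 nM; the measured step is a 33-fold higher number from compound 1 to compound 2 (1.52 log units; beyond the scatter). Compound 3 `Nc1cccc(-c2cn3nc(-c4ccc(Cl)cc4)sc3n2)c1` returns only a limit of this assay, >= 250000 nM, as recorded in the limit of >= 250000 nM in this assay, at which 1 of the 3 values shown sits, and offers no number to compare.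

Compound 4 `C=C(Br)C(=O)Nc1cccc(-c2cn3nc(-c4cccc(OC)c4)sc3n2)c1` is not yet measured. Against compound 2 the change is 3-methoxyphenyl in place of 4-methoxybenzyl on an aromatic carbon. Among the compounds with values here, the only measured step that bears on this move is the large one from a directly bound aryl to a benzyl, a 33-fold higher number from compound 1 to compound 2 (1.52 log units; beyond the scatter); compound 4 reverses that move, though it carries a single methoxy where compound 1 carries two, so a full return to the value of compound 1 is not assumed. The expected step from compound 2 to compound 4 in this assay is therefore large and downward, a 13-fold lower number from compound 2 to compound 4 (1.10 log units; beyond the scatter). Compound 4 is expected to give about 110 nM in this assay, estimated between 30 nM and 400 nM.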

Compound 4, half-maximal inhibitory concentration: 580 nM
Compound 4: middle estimate off by 5.3-fold (0.72 log units), on the low side; the whole stated range lies below it.
By their numbers in this assay, from the lowest: compound 1; then compound 4; then compound 2. At a limit, above all of these: compound 3.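

Replacing the 4-methoxybenzyl with a directly bound 3-methoxyphenyl at this carbon gains little in this assay: a 2.4-fold lower number from compound 2 to compound 4 (0.38 log units; beyond the scatter). The directly bound aryl alone therefore does not restore the potency of compound 1, since the change of hydrogen in place of methoxy on that aryl gives a 14-fold higher number from compound 1 to compound 4 (1.14 log units; beyond the scatter). Within the directly bound aryl pair, the ring substitution is thus a large determinant of the value, and the step from compound 2 to compound 4 is only modest, though that swap alters both the attachment and the methoxy placement at once. Nothing shown gives a cause for either step.

The compounds shown do not separate the effect of the attachment from that of the methoxy placement on the aryl. They also leave open whether an amine or a carboxylic acid in place of the methoxy would be tolerated on this aryl.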